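The compounds below may be only part of what the source reports. "The series", "measured", "known", "first", "only" and "open" are said of these compounds alone.

Three compounds have been measured in a physicochemical assay for acid dissociation:
compound 1 `COc1cccc(CNCCCNc2ccnc3cc(Oc4ccc(Cl)cc4)ccc23)c1O` gives 9.28;
compound 2 `COc1ccc(F)cc1CNCCCNc1ccnc2cc(C3CCCCC3)ccc12` gives 9.47;
compound 3 `COc1ccc(F)cc1CNCCCNc1ccnc2cc(Cc3ccc(C#N)cc3)ccc12` gives 9.47.

Compound 3 stands level with compound 2, and the two together mark the top of these three numbers; the gap from compound 3 down to compound 1 is within the scatter. For the measured compounds named here, the only single-point step in this set, no change at the digits printed from compound 2 to compound 3 (within the scatter), shows that swapping one group for another on that aromatic carbon left the number unchanged. Compound 4 `COc1ccc(F)cc1CNCCCNc1ccnc2cc(Oc3ccc(Cl)cc3)ccc12` differs from compound 3 by 4-chlorophenoxy in place of 4-cyanobenzyl on an aromatic carbon. Compound 1 already carries a 4-chlorophenoxy group and its value sits close to that of compound 3. Compound 4 is therefore expected to show a number 0.07 log units lower from compound 3 to compound 4 (within the scatter), nothing beyond the scatter. Compound 4 is estimated at 9.4, between 9.1 and 9.7, in this assay.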

Compound 4, acid dissociation constant: 9.28
The estimate for compound 4 lay 0.12 log units above the measured number, within the range that was stated.
By their numbers in this assay, from the lowest: compounds 1, 4, 2 and 3 (each within the scatter of the next).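

In this assay, 4-chlorophenoxy on this aromatic carbon cannot be told apart from either group it replaces, with a number 0.19 log units lower from compound 3 to compound 4 (within the scatter) for 4-cyanobenzyl and a number 0.19 log units lower from compound 2 to compound 4 (within the scatter) for cyclohexyl. A second place can now also be read: 5-fluoro-2-methoxyphenyl in place of 2-hydroxy-3-methoxyphenyl leaves no change at the digits printed from compound 1 to compound 4 (within the scatter). No supporting measurement is available to explain these results. As far as these compounds go, whether an amine or a carboxylic acid on this aromatic carbon would shift the number beyond the scatter remains open, as does the effect of a longer chain.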